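The source may report more compounds than this note shows. Statements on the series, on what has been measured and on what is new or still open speak of the compounds shown alone.

Compound 1 `CC(C)c1n[nH]c2c(NCc3ccc(-c4ccccn4)cc3)nc(SCC(O)CO)nc12`, compound 2 `CC(C)c1n[nH]c2c(NCc3ccc(-c4ccccn4)cc3)nc(SCC3CNC(=O)O3)nc12` and compound 3 `CC(C)c1n[nH]c2c(NCc3ccc(-c4ccccn4)cc3)nc(SCC(O)CN)nc12` share one core and differ only in the chain on the sulfur. In a functional assay on HT cells (Homo sapiens) for antiproliferative activity, read by fluorescence, with a stated time of 72 h (on this read-out lower numbers stand for stronger inhibition of growth and higher numbers for weaker inhibition of growth), compound 1 gives 21 nM, compound 2 gives 80 nM and compound 3 gives 55 nM. Compound 2 thus stands at the high end of these numbers, level with compound 3: a 1.5-fold lower number from compound 2 to compound 3 (0.16 log units; within the scatter) stays within the scatter, whereas a 3.8-fold higher number from compound 1 to compound 2 (0.58 log units; beyond the scatter) is modest but beyond it. The remaining step, a 2.6-fold higher number from compound 1 to compound 3 (0.42 log units; beyond the scatter), is also modest.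

Compound 4 `CSc1nc(NCc2ccc(-c3ccccn3)cc2)c2[nH]nc(C(C)C)c2n1` carries a more drastic change: hydrogen in place of 2-oxo-1,3-oxazolidin-5-yl on a saturated chain carbon bound to a sulfur, which turns the ((2-oxo-1,3-oxazolidin-5-yl)methyl)sulfanyl into methylsulfanyl. Within the data shown here, no measured compound carries methylsulfanyl, so the three steps offer only a rough guide to its effect. As none of them is more than modest, the expectation in this assay is a small step with no firm direction. The estimate means a 1.3-fold lower number from compound 2 to compound 4 (0.12 log units; within the scatter), an expected change within the scatter. For compound 4 the expected value is 60 nM, with an estimated range from 20 nM to 200 nM.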

Compound 4, concentration for 50% growth inhibition: 783 nM
Estimate against measurement, compound 4: 13-fold (1.12 log units) below; the measured number lies above the stated range.
By their numbers in this assay, from the lowest: compound 1; then compounds 3 and 2 (each within the scatter of the next); then compound 4.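

In this assay, cutting the chain on the sulfur back to methylsulfanyl raises the number whichever chain is removed: a 9.8-fold higher number from compound 2 to compound 4 (0.99 log units; beyond the scatter), a 14-fold higher number from compound 3 to compound 4 (1.15 log units; beyond the scatter) and a 37-fold higher number from compound 1 to compound 4 (1.57 log units; beyond the scatter). Each of these steps exceeds every step among compound 1, compound 2 and compound 3, so at this position, having one of these three chains matters more than which one it is. Nothing shown here explains the loss.

The compounds shown leave open whether chain length alone carries the difference or whether the hydroxy, amino or oxazolidinone groups on the chain are needed. A plain propyl chain on the sulfur, set against a chain bearing a carboxylic acid, would help to separate these two readings.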